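Solubility notes: from compound 2 to compound 3

This account rests on a few compounds, and the source may have more. Where it says the series, first, only, none or still open, it means among the compounds named here.

Of the compounds shown here, two carry measured numbers so far. In a physicochemical assay for solubility, read by LC-MS, in phosphate buffer, with a stated time of 24 h, at pH 7.4 (on this read-out higher numbers stand for higher solubility and lower numbers for lower solubility), compound 1 (`Cc1ncc(-c2cnc(NCc3c(F)ccc4c3CCO4)c3cn[nH]c(=O)c23)n1C`) gives 15000 nM. In this assay compound 2 (`CN(c1ccn(C)n1)c1cnc(NCc2c(F)ccc3c2CCO3)n2cnnc12`) gives 130000 nM, the higher of the two numbers, and the gap between them lies beyond the usual scatter. The two differ in more than one place, so their gap isolates no single change.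

Compound 3 (`O=C1CC2(CC2)CN1c1cnc(NCc2c(F)ccc3c2CCO3)n2cnnc12`) has not yet been measured. Relative to compound 2, the change is a group of 8 heavy atoms (6 carbon, 1 nitrogen, 1 oxygen; one three-membered non-aromatic ring of carbon only, one five-membered non-aromatic ring with 1 hetero atom) in place of a group of 8 heavy atoms (5 carbon, 3 nitrogen; one five-membered aromatic ring with 2 hetero atoms), on an aromatic carbon. The methyl(1-methyl-1H-pyrazol-3-yl)amino group leaves, and a group with no common name enters on the same aromatic carbon.

Among the compounds with values here, no measured pair shows this exchange, so the expectation rests on compound 2 at 130000 nM alone and stays wide. The expected change is a 1.4-fold lower number from compound 2 to compound 3 (0.16 log units; within the scatter), a small downward move that is not expected to exceed the scatter. The estimated value for compound 3 is 90000 nM, with an expected range of 30000 nM to 250000 nM.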

Compound 3, solubility: 130000 nM
Beside the measured number, compound 3's estimate is 1.4-fold (0.16 log units) below it, and the stated range covers the measured number.
By their numbers in this assay, from the lowest: compound 1; then compounds 2 and 3 (each within the scatter of the next).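

Working notes on the series. In this assay, within the data shown here, replacing the methyl(1-methyl-1H-pyrazol-3-yl)amino group on this aromatic carbon, two atoms from the ring nitrogen, gives no change at the digits printed from compound 2 to compound 3 (within the scatter), the first step that isolates a single place. At this position, the read-out therefore does not separate a group with one five-membered aromatic ring with 2 hetero atoms and 3 hydrogen-bond acceptors from a group with a three-membered carbon ring, a five-membered non-aromatic ring with 1 hetero atom and 1 hydrogen-bond acceptor, although the two groups have the same count of 8 heavy atoms. No measurement is available that could account for this result.

Among these compounds, the single step does not show whether a differently built group on the same aromatic carbon, such as a morpholine, a primary amine or a carboxylic acid, would also stay within the scatter of compound 2. Going by these compounds, compound 1 differs from compound 2 and compound 3 in more than one place, so it remains open whether this exchange would read the same way on the core of compound 1.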